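Phenyl for Thiophen-3-yl at the Top of the Solubility Range

The source may report more compounds than this note shows. Statements on the series, on what has been measured and on what is new or still open speak of the compounds shown alone.

Compound 1 `CC(C)(C)C(=O)N1Cc2c(NC(=O)C3CCNCC3)n[nH]c2C1(C)C`: > 225000 nM in a physicochemical assay for solubility, at pH 7 (on this read-out lower numbers stand for lower solubility and higher numbers for higher solubility), a limit of the assay.
Compound 2 `CC(C)(C)C(=O)N1Cc2c(NC(=O)c3ccc(F)cc3)n[nH]c2C1(C)C`: 235000 nM in this assay.
Compound 3 `CN1CCC(C(=O)N2Cc3c(NC(=O)c4ccsc4)n[nH]c3C2(C)C)CC1`: > 225000 nM in this assay, again a limit of the assay.

Compound 3 stands at the ceiling of the numbers shown: its result is a limit rather than a number, and (the limit of > 225000 nM in this assay, at which 2 of the 3 values shown sit). Compound 4 `CN1CCC(C(=O)N2Cc3c(NC(=O)c4ccccc4)n[nH]c3C2(C)C)CC1` differs from compound 3 in one place: phenyl in place of thiophen-3-yl on a carbonyl carbon. Going by the values given here, only one step between measured compounds that differ in one place is available, a step that the limit leaves unreadable from compound 1 to compound 2; it concerns another position and another exchange, and the limit on compound 1 leaves its size unreadable. Among the compounds with values here, no measured pair therefore bears directly on the exchange of thiophen-3-yl for phenyl. Within the data shown here, compound 2, the one compound with a number, reads 235000 nM. All three measured compounds thus sit at or near the top of the range shown, with no step of readable size among them.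

Compound 4 is expected to remain in that region, so the expected step of a number no higher from compound 3 to compound 4 (the limit leaves the size open) should carry no size beyond the scatter. The estimate for compound 4 in this assay is 225000 nM, with a range from 110000 nM to 320000 nM, and it is quite likely that the assay again reports only a limit.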

Compound 4, solubility: > 225000 nM
Compound 4 ended at the assay's limit (the forecaster's own chance of this, stated with the estimate: 60%); the middle value lies on the limit itself.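

Compound 3 and compound 4 both end at a limit of this assay, so no step between them can be read and the exchange of thiophen-3-yl for phenyl has no readable size: the limit of > 225000 nM in this assay, at which 3 of the 4 values shown sit.

The compounds shown leave open whether phenyl and thiophen-3-yl on this carbonyl carbon differ at all in this assay.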